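The compounds below may be only part of what the source reports. "The series", "measured", "known", "first", "only" and "open" are said of these compounds alone.

Compound 1 `Oc1cccc(-c2nc(N3CCCCC3)c3nc[nH]c3n2)c1`: 63.1 nM
Compound 2 `CN1CCN(c2nc(-c3cccc(O)c3)nc3[nH]cnc23)CC1`: 501 nM
Compound 3 `CN1CCN(c2nc(-c3ccc(Cl)cc3)nc3[nH]cnc23)CC1`: 39.8 nM

All three share one core and were measured in an assay on cells for displacement of a labelled ligand from adenosine receptor A3 (Homo sapiens), read by scintillation counting and radioligand binding, with a stated time of 180 min; on this read-out higher numbers stand for weaker inhibition and lower numbers for stronger inhibition. Compound 1, with 63.1 nM, stands second highest of the three numbers; compound 3 gives 39.8 nM, and the two lie within the scatter of each other. Compound 2 is further off, giving a 7.9-fold higher number from compound 1 to compound 2 (0.90 log units; beyond the scatter).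

The unmeasured compound 4 `Oc1ccc(-c2nc(N3CCCCC3)c3nc[nH]c3n2)cc1` keeps the core and the piperidin-1-yl group of compound 1 and differs only by 4-hydroxyphenyl in place of 3-hydroxyphenyl on an aromatic carbon. Neither measured step bears directly on this: a 7.9-fold higher number from compound 1 to compound 2 (0.90 log units; beyond the scatter) changes the piperidin-1-yl group, and a 13-fold lower number from compound 2 to compound 3 (1.10 log units; beyond the scatter) replaces the whole 3-hydroxyphenyl group with 4-chlorophenyl. Among the measured compounds shown here, the only change here is where the hydroxyl sits on the phenyl ring, and no measured pair shows such a move. The step from compound 1 to compound 4 in this assay is therefore expected to be small, with a wide uncertainty and no clear direction, as a 1.6-fold higher number from compound 1 to compound 4 (0.20 log units; within the scatter). Compound 4 is estimated at 100 nM, in the range 25 nM to 400 nM.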

Compound 4, inhibition constant: 39.8 nM
Compound 4: the middle estimate sits 2.5-fold (0.40 log units) above what was measured, and the stated range covers the measured number.
By their numbers in this assay, from the lowest: compounds 3, 4 and 1 (each within the scatter of the next); then compound 2.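

With the piperidin-1-yl group kept, replacing 3-hydroxyphenyl with 4-hydroxyphenyl gives a 1.6-fold lower number from compound 1 to compound 4 (0.20 log units; within the scatter) in this assay. This is the only pair shown that changes nothing except where the hydroxyl sits on the phenyl ring, which is attached to the shared core at the aromatic carbon between two ring nitrogen atoms. The two groups have the same atoms joined differently, and this read-out does not tell them apart, while no supporting measurement is available to explain the result.

As far as these compounds go, it remains open whether the hydroxyl position matters as little when 4-methylpiperazin-1-yl stands in place of piperidin-1-yl. The compounds shown also leave open how a phenyl ring carrying a methoxy group, an amine or a carboxylic acid would read in place of the hydroxyl.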